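A few compounds are considered here, and "the series" means these few. Any claim that something is new, unique, unknown or untested is made for them only; others in the source may bear on it.

Measured in a functional assay on KYSE-410 cells (Homo sapiens) for antiproliferative activity, read by MTT assay, with a stated time of 72 h; on this read-out higher numbers stand for weaker inhibition and lower numbers for stronger inhibition:
- compound 1 `O=C(Nc1cccc(F)c1)c1cc(=O)[nH]c2cc(C3CC3)ccc12` gives > 20000 nM
- compound 2 `O=C(Nc1cccc(F)c1)c1cc(=O)[nH]c2cc(-c3ccc(F)nc3)ccc12` gives > 20000 nM
- compound 3 `Cc1cc(-c2ccc3c(C(=O)Nc4cccc(F)c4)cc(=O)[nH]c3c2)c(C)cc1F` gives > 20000 nM

Compound 3 stands at > 20000 nM, which is a limit and not a number. Within the data shown here, the other two entries are limits as well, so the series so far is summed up by the limit of > 20000 nM in this assay, at which 3 of the 3 values shown sit.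

The next change leads to compound 4 `C#Cc1ccc2c(C(=O)Nc3cccc(F)c3)cc(=O)[nH]c2c1`, with ethynyl in place of 4-fluoro-2,5-dimethylphenyl on an aromatic carbon.

Among the measured compounds shown here, three measured steps bear on this change: a step that the two limits leave unreadable from compound 1 to compound 3, a step that the two limits leave unreadable from compound 2 to compound 3 and a step that the two limits leave unreadable from compound 1 to compound 2. None of them has a readable size, so they give no direction. Cyclopropyl, 6-fluoropyridin-3-yl and 4-fluoro-2,5-dimethylphenyl nevertheless all leave the series at the same limit. On that basis, no step beyond the scatter is expected in this assay, and the expected step is a number no higher from compound 3 to compound 4 (the limit leaves the size open). A further limit is the most likely report.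

For compound 4 the estimated value is 20000 nM, with an expected range from 8000 nM to 50000 nM.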

Compound 4, half-maximal inhibitory concentration: 9700 nM
For compound 4 the middle estimate is 2.1-fold (0.31 log units) above the measured one; low and high end bracket the measured number.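

In this assay this position responds to its substituent for the first time, and ethynyl is the only group shown that takes the series off its limit: the limit of > 20000 nM in this assay, at which 3 of the 4 values shown sit. The change to ethynyl reads as an at least 2.0-fold lower number from compound 3 to compound 4 (0.31 log units; beyond the scatter), as an at least 2.0-fold lower number from compound 2 to compound 4 (0.31 log units; beyond the scatter) and as an at least 2.0-fold lower number from compound 1 to compound 4 (0.31 log units; beyond the scatter). Each of these is only a minimum size, set against a limit, and the steps among compound 1, compound 2 and compound 3 cannot be read.

On these data alone, whether the triple bond itself carries these steps stays open, and a nitrile or a propynyl group on the same aromatic carbon would speak to that. Also open, as far as these compounds go, is how a group such as an amine or a carboxylic acid at this position would compare with compound 4.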